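Ring substitution in a diaryl pyrazole benzamide series

This account rests on a few compounds, and the source may have more. Where it says the series, first, only, none or still open, it means among the compounds named here.

Measured so far in an assay on HEK293 cells for displacement of a labelled ligand from metabotropic glutamate receptor 5 (Rattus norvegicus); a higher number here means a weaker inhibitor, a lower number a stronger inhibitor:
- compound 1 `O=C(Nc1cc(-c2ccccc2)nn1-c1ccccc1)c1ccccc1`: 4180 nM
- compound 2 `Cc1ccc(C(=O)Nc2cc(-c3ccccc3)nn2-c2ccccc2)cc1`: 780 nM
- compound 3 `O=C(Nc1cc(-c2ccccc2)nn1-c1ccccc1)c1ccc([N+](=O)[O-])cc1`: 250 nM

Compound 3 has the lowest number of the three. The steps that reach it are a 17-fold lower number from compound 1 to compound 3 (1.22 log units; beyond the scatter) and a 3.1-fold lower number from compound 2 to compound 3 (0.49 log units; beyond the scatter); the remaining step is a 5.4-fold lower number from compound 1 to compound 2 (0.73 log units; beyond the scatter). All three steps sit on the benzamide ring.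

Compound 4 `O=C(Nc1cc(-c2ccccc2)nn1-c1ccccc1Br)c1ccc([N+](=O)[O-])cc1` differs from compound 3 by bromo in place of hydrogen on an aromatic carbon. This change sits on the other phenyl ring, the one carried by the ring nitrogen, ortho to a large group. Among the measured compounds shown here, none of the measured steps touches that ring, so nothing here bears directly on the change; the measured steps only show that substituents on the benzamide ring moved this assay by modest to large amounts, which says nothing about the second ring. For the measured compounds named here, with no relevant step, the expectation for compound 4 is no step beyond the scatter, a 1.2-fold higher number from compound 3 to compound 4 (0.08 log units; within the scatter). Compound 4 is therefore estimated at 300 nM, with a range of 90 nM to 1000 nM. Going by the values given here, the range is wide: no measured step covers this ring.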

Compound 4, inhibition constant: 120 nM
For compound 4 the middle estimate is 2.5-fold (0.40 log units) above the measured one; the range from low to high includes it.
By their numbers in this assay, from the lowest: compound 4; then compound 3; then compound 2; then compound 1.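

Bromo on the phenyl ring carried by the ring nitrogen, ortho to a large group, does not cost binding in this assay: the change from phenyl to 2-bromophenyl gives a 2.1-fold lower number from compound 3 to compound 4 (0.32 log units; beyond the scatter). This ring therefore also moves the number, on a benzamide already carrying nitro, and compound 4 now has the lowest number of the four. No measurement shown gives a reason for this step.

From the compounds shown here alone, it remains open whether bromo would give a similar step with the unsubstituted benzamide of compound 1 or the methyl benzamide of compound 2, since the size of this step is known only alongside nitro. Also open, going by these compounds, is how chloro, methoxy, an amine or a longer chain would read at this place, and whether other places on this ring accept bromo.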